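From Benzyl to Cyanomethyl: What Compound 4 Might Tolerate

A few compounds are considered here, and "the series" means these few. Any claim that something is new, unique, unknown or untested is made for them only; others in the source may bear on it.

Compound 1 `O=C1N(Cc2ccccc2Cl)c2cccn2S(=O)(=O)N1Cc1cccc(Br)c1`: in an ADME assay on MT4 cells (Homo sapiens) for cytotoxicity, read by MTT assay, with a stated time of 5 days (a higher number here means that more compound is tolerated, a lower number that less compound is tolerated), compound 1 gives only a limit, > 260000 nM.
Compound 2 `O=C1N(Cc2ccccc2)c2cccn2S(=O)(=O)N1Cc1ccccc1`: in this assay compound 2 gives 196000 nM.
Compound 3 `O=C1N(Cc2ccccc2)c2cccn2S(=O)(=O)N1Cc1cccc(F)c1`: in this assay compound 3 gives only a limit, > 288000 nM.

For the measured compounds named here, compound 2 stands as the only compound of the three with a number in this assay; the other two values are limits of the assay. Going by the values given here, the only measured step is an at least 1.4-fold higher number from compound 2 to compound 3 (0.16 log units; that floor lies within the scatter), which is within the scatter and concerns a different change.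

Compound 4 `N#CCN1C(=O)N(Cc2ccccc2)S(=O)(=O)n2cccc21` differs from compound 2 by cyano in place of phenyl on a saturated chain carbon bound to an amide-type nitrogen in a ring. Among the compounds with values here, no measured step covers this change, and the one step that exists in this assay is too small to point in any direction. Compound 4 is therefore expected to sit close to compound 2, with a step of a 1.1-fold higher number from compound 2 to compound 4 (0.05 log units; within the scatter) that stays within the scatter. For compound 4 the estimate in this assay is 220000 nM, with a range from 100000 nM to 500000 nM.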

Compound 4, half-maximal cytotoxic concentration: 180000 nM
Estimate against measurement, compound 4: 1.2-fold (0.09 log units) above; low and high end bracket the measured number.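

In this assay, replacing benzyl with cyanomethyl gives a 1.1-fold lower number from compound 2 to compound 4 (0.04 log units; within the scatter), so a phenyl of 6 heavy atoms on the saturated chain carbon bound to an amide-type nitrogen in a ring gives way to a cyano of 2 heavy atoms with no readable shift. The earlier compounds shown here all kept an aromatic ring at this place and so could not show this, whereas compound 4 has none there and still returns a number rather than a limit. Nothing among the data shown offers a cause for this outcome.

Left open is whether a carboxylic acid or a primary amine in place of the cyano would hold the number in this assay. From the compounds shown here alone, whether a longer chain carrying the nitrile would do so also remains open.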